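A few compounds are considered here, and "the series" means these few. Any claim that something is new, unique, unknown or untested is made for them only; others in the source may bear on it.

Measured compounds in an assay on isolated protein (Cricetulus griseus) for binding affinity to Alpha-1B adrenergic receptor (Mesocricetus auratus), read by radioligand binding; a higher number here means a weaker inhibitor, a lower number a stronger inhibitor:
- compound 1 `CCS(=O)(=O)Nc1cccc(Cc2c[nH]cn2)c1C`: 8130 nM
- compound 2 `Cn1cnc(C2CCCc3c(NS(C)(=O)=O)cccc32)c1`: 2040 nM

Compound 2 holds the lowest of the two numbers in this assay; its nearest neighbour is compound 1, which gives a number higher by a margin that lies beyond the usual scatter. Compound 1 and compound 2 differ in more than one place, so no single step can be read between them; the two values only show that compound 2 is the stronger inhibitor of the pair.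

Compound 3 `Cn1cncc1C1CCCc2c(NS(C)(=O)=O)cccc21` has not yet been measured. It shares all atoms with compound 2 but joins them differently: 1-methyl-1H-imidazol-5-yl in place of 1-methyl-1H-imidazol-4-yl on a saturated ring carbon. The ring keeps its methyl and its two nitrogens; only the attachment point on the five-membered ring moves.

Within the data shown here, no step between measured compounds speaks to this kind of change, so no direction can be drawn from the data. The expectation for compound 3 in this assay is a step from compound 2 of a 1.5-fold higher number from compound 2 to compound 3 (0.17 log units; within the scatter), set close to no change, with wide uncertainty in both directions. The estimate for compound 3 in this assay is 3000 nM, within a range from 800 nM to 12000 nM.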

Compound 3, inhibition constant: < 10000 nM
Compound 3: only a limit was reported; the forecaster's own chance of this, stated with the estimate: 10%; the middle value does not contradict the limit.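

In this assay compound 3 is reported only as a limit, < 10000 nM, so no step from compound 2 to compound 3 can be read: the limit of < 10000 nM in this assay, at which 1 of the 3 values shown sits.

The compounds shown leave open whether 1-methyl-1H-imidazol-5-yl in place of 1-methyl-1H-imidazol-4-yl on a saturated ring carbon strengthens, weakens or leaves unchanged the inhibition in this assay.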